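This account rests on a few compounds, and the source may have more. Where it says the series, first, only, none or still open, it means among the compounds named here.

Working notes on the series in a functional assay on MOLT-4F cells (Homo sapiens) for antiproliferative activity; a higher number here means a weaker inhibitor of growth, a lower number a stronger inhibitor of growth. Compound 1 `CCCCCOCCCCCCC/C=C1\CC(CO)(COC(=O)C(C)(C)C)OC1=O` gives 1.03 ug/mL. Compound 2 `CC(=O)NCCCCCCCCCCCCCCC/C=C1\CC(CO)(COC(=O)C(C)(C)C)OC1=O` gives 6.35 ug/mL. The step between them is a 6.2-fold higher number from compound 1 to compound 2 (0.79 log units; beyond the scatter). Compound 3 `CC(C)(C)C(=O)OCC1(CO)C/C(=C\CCCCCCCCCCCCCCC=O)C(=O)O1` reaches only a limit of the assay, > 10 ug/mL, one of the values sitting at the limit of > 10 ug/mL in this assay, at which 1 of the 3 values shown sits. The steps of an at least 9.7-fold higher number from compound 1 to compound 3 (0.98 log units; beyond the scatter) and an at least 1.5-fold higher number from compound 2 to compound 3 (0.19 log units; that floor lies within the scatter) both run toward that limit, the second with a floor inside the scatter. Compound 4 `COC(=O)CCCCCCCCCCCCCC/C=C1\CC(CO)(COC(=O)C(C)(C)C)OC1=O` differs from compound 3 by methoxy in place of hydrogen on a carbonyl carbon. No measured step alters a carbonyl carbon in this way, and the shown steps bear on it only indirectly. Compound 4 is expected to stay near the limit, with an at least 1.2-fold lower number from compound 3 to compound 4 (0.09 log units; that floor lies within the scatter) small or none beyond the scatter. The estimate for compound 4 is 8 ug/mL, ranging from 3 ug/mL to 25 ug/mL.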

Compound 4, concentration for 50% growth inhibition: > 10 ug/mL
Compound 4 gave a limit, no number (the forecaster's own chance of this, stated with the estimate: 40%); at least 1.2-fold (0.09 log units) between middle value and limit.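

In this assay compound 4, with methoxycarbonyl in place of formyl, gives only a limit of the assay, > 10 ug/mL: the limit of > 10 ug/mL in this assay, at which 2 of the 4 values shown sit. Methoxycarbonyl therefore joins formyl in falling well short of the pentyloxy compound, with an at least 9.7-fold higher number from compound 1 to compound 4 (0.98 log units; beyond the scatter), while against the acetamido compound there is an at least 1.5-fold higher number from compound 2 to compound 4 (0.19 log units; that floor lies within the scatter). The step between the two limits cannot be read, so formyl and methoxycarbonyl cannot be ordered.

As far as these compounds go, it stays open whether a carboxylic acid in place of methoxycarbonyl would bring a measurable value. From the compounds shown here alone, the true distance of compound 4 from compound 2 also stays open.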